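Changing the Aryl Group on Compound 3: an Estimate

The compounds below may be only part of what the source reports. "The series", "measured", "known", "first", "only" and "open" are said of these compounds alone.

Of the compounds shown here, three built on one shared core have been measured in a functional assay on A549 cells (Homo sapiens) for cytotoxicity, read by MTT assay, with a stated time of 72 h; on this read-out higher numbers stand for weaker inhibition and lower numbers for stronger inhibition. Compound 1 `CN(C)CCn1cnnc1-c1cc(Oc2ccc(NC(=O)N/N=C/c3c(Cl)cccc3Cl)cc2F)ccn1` gives 1410 nM, compound 2 `CN(C)CCn1cnnc1-c1cc(Oc2ccc(NC(=O)N/N=C/c3ccc(O)c(Br)c3)cc2F)ccn1` gives 1370 nM, and compound 3 `CN(C)CCn1cnnc1-c1cc(Oc2ccc(NC(=O)N/N=C/c3ccccc3)cc2F)ccn1` gives 1860 nM, the highest of the three numbers, although its separations from the others, a 1.3-fold higher number from compound 1 to compound 3 (0.12 log units; within the scatter) and a 1.4-fold higher number from compound 2 to compound 3 (0.13 log units; within the scatter), lie within the scatter, as does a 1.0-fold lower number from compound 1 to compound 2 (0.01 log units; within the scatter). Compound 4 `COc1cc(/C=N/NC(=O)Nc2ccc(Oc3ccnc(-c4nncn4CCN(C)C)c3)c(F)c2)cc(OC)c1OC` differs from compound 3 by 3,4,5-trimethoxyphenyl in place of phenyl on a carbon with a double bond to nitrogen. Every measured step exchanges the aryl group at this same place, and none moved the number beyond the scatter, so no step beyond the scatter is expected in this assay here either. Compound 4 is therefore estimated at 1700 nM, within 900 nM to 3200 nM, an expected step of a 1.1-fold lower number from compound 3 to compound 4 (0.04 log units; within the scatter).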

Compound 4, half-maximal inhibitory concentration: > 100000 nM
Compound 4: a limit, no number; the forecaster's own chance of this, stated with the estimate: 3%; middle value at least 58-fold (1.76 log units) from the limit.
By their numbers in this assay, from the lowest: compounds 2, 1 and 3 (each within the scatter of the next). At a limit, above all of these: compound 4.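

In this assay compound 4 stands at a limit, not a number: the limit of > 100000 nM in this assay, at which 1 of the 4 values shown sits. Among these compounds, the 3,4,5-trimethoxyphenyl group brings the only steps at this place that lie beyond the scatter: an at least 53-fold higher number from compound 3 to compound 4 (1.73 log units; beyond the scatter), an at least 72-fold higher number from compound 2 to compound 4 (1.86 log units; beyond the scatter) and an at least 70-fold higher number from compound 1 to compound 4 (1.85 log units; beyond the scatter). The aryl group on a carbon with a double bond to nitrogen can therefore matter greatly in this assay, which the three earlier exchanges did not show.

The compounds shown leave open whether a phenyl carrying a single methoxy group would already bring such a step, and how an amine or a carboxylic acid on that aryl group would read.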